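This account rests on a few compounds, and the source may have more. Where it says the series, first, only, none or still open, it means among the compounds named here.

In a functional assay on MCF7 cells (Homo sapiens) for cytotoxicity, read by MTT assay, with a stated time of 24 h, tested at 0.64 ug/mL (a lower number here means a weaker effect, a higher number a stronger effect of the compound at the concentration tested), the measured compounds are:

compound 1 `Cn1c(-c2ccc(NC(=O)CSc3nc4cc(Cl)ccc4o3)cc2)nc(-c2ccccc2)c1-c1ccccc1`: 2.4%
compound 2 `Cn1ccnc1SCC(=O)Nc1ccc(-c2nc(-c3ccccc3)c(-c3ccccc3)n2C)cc1`: 10.3%

Compound 2 stands highest of the two numbers, with compound 1 as its nearest neighbour, the two separated by a step of a number 7.9 percentage points higher from compound 1 to compound 2 (within the scatter). Compound 3 `CN(C)/C=C/N1CCN(CC(=O)Nc2ccc(-c3nc(-c4ccccc4)c(-c4ccccc4)n3C)cc2)CC1` has not yet been measured. The change from compound 2 to compound 3 is 4-(2-(dimethylamino)ethenyl)piperazin-1-yl in place of (1-methyl-1H-imidazol-2-yl)sulfanyl on a saturated chain carbon bound to a carbonyl carbon. Within the data shown here, only one measured step exists, and it exchanged the group carried on the sulfur while staying within the scatter; no measured step removes the sulfur itself or introduces a piperazine, so the new change is covered only loosely. On that basis the step from compound 2 to compound 3 is estimated at a number 1.3 percentage points lower from compound 2 to compound 3 (within the scatter), with nothing beyond the scatter expected. Compound 3 is therefore expected to give 9% in this assay, within a range of 0% to 28%.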

Compound 3, a percentage reported as activity, at one concentration (the size of the read-out at that concentration, not a potency): 1.2%
Compound 3: the middle estimate sits 7.8 percentage points above what was measured, within the range that was stated.
By their numbers in this assay, from the lowest: compounds 3, 1 and 2 (each within the scatter of the next).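

In this assay the entry of 4-(2-(dimethylamino)ethenyl)piperazin-1-yl on a saturated chain carbon bound to a carbonyl carbon gives a number 9.1 percentage points lower from compound 2 to compound 3 (within the scatter) and a number 1.2 percentage points lower from compound 1 to compound 3 (within the scatter) as the two sulfanyl groups leave. The earlier step exchanged only the group carried on the sulfur, whereas these steps remove the sulfur itself and bring in a six-membered non-aromatic ring, and neither step leaves the scatter. At this one concentration, the three groups at this place are therefore not told apart by the assay.

As far as these compounds go, whether a primary amine, a carboxylic acid or a longer chain at this place would give a reading beyond the scatter remains open. Nothing available explains why these three readings lie so close.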